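A Saturated Chain Gives Way to a Double Bond

The compounds below may be only part of what the source reports. "The series", "measured", "known", "first", "only" and "open" are said of these compounds alone.

Measured compounds:
compound 1 `Cc1cc(/C=C/C#N)cc(C)c1Oc1cc(Nc2ccc(C#N)cc2)c(N)cc1[N+](=O)[O-]`: 0.29 ug/mL
compound 2 `COC(=O)c1cc(N)c(Nc2ccc(C#N)cc2)cc1Oc1c(C)cc(CCC#N)cc1C`: 21.8 ug/mL

For the measured compounds named here, in a physicochemical assay for solubility, with a stated time of 4 h, at pH 2.0 (a lower number here means a less soluble compound, a higher number a more soluble compound), compound 2 stands at 21.8 ug/mL, the higher of the two numbers so far. Compound 1 gives 0.29 ug/mL, and the gap between the two compounds lies beyond the scatter.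

The next compound is compound 3 `COC(=O)c1cc(N)c(Nc2ccc(C#N)cc2)cc1Oc1c(C)cc(/C=C/C#N)cc1C`, which has 2-cyanoethenyl in place of 2-cyanoethyl on an aromatic carbon. No single-point comparison has been measured for this change. Compound 1 also carries 2-cyanoethenyl, but it differs from compound 3 elsewhere too, so compound 1 at 0.29 ug/mL offers only a weak hint of direction. A moderate fall in this assay is therefore expected, with an estimated 3.6-fold lower number from compound 2 to compound 3 (0.56 log units; beyond the scatter). For compound 3 the estimated value is 6 ug/mL, with an expected range of 1.5 ug/mL to 22 ug/mL.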

Compound 3, solubility: 1.75 ug/mL
Compound 3: middle estimate off by 3.4-fold (0.54 log units), on the high side, and the stated range covers the measured number.
By their numbers in this assay, from the lowest: compound 1; then compound 3; then compound 2.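

In this assay, for the compounds shown here, replacing 2-cyanoethyl with 2-cyanoethenyl on the aromatic carbon para to a large group gives the first single-place reading at this position, and it is a large step (a 12-fold lower number from compound 2 to compound 3 (1.10 log units; beyond the scatter)). Compound 3 also connects the two earlier compounds: with 2-cyanoethenyl held constant, methoxycarbonyl in place of nitro gives a modest step (a 6.0-fold higher number from compound 1 to compound 3 (0.78 log units; beyond the scatter)), so the wide gap between compound 1 and compound 2 now resolves into two single-place steps, each beyond the scatter. No measurement at hand explains why either change moves the number.

Going by these compounds, it remains open whether the double bond would give a step of similar size in a compound carrying nitro. Also open, on these data alone, is how an amine, a carboxylic acid or a longer chain at this position would compare.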